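The compounds below may be only part of what the source reports. "The series", "measured", "known", "first", "only" and "open" are said of these compounds alone.

The compounds measured so far:

compound 1 `Cn1ccnc1[C@@H](CC(=O)O)c1ccc(OCc2cccc(-c3ccccc3S(C)(=O)=O)c2)cc1` — in an assay on CHO cells for agonist activity at Free fatty acid receptor 1 (Homo sapiens), read by luminescence, with a stated time of 20 s, in the presence of a further agent that is not named here (on this read-out lower numbers stand for an effect already at smaller amounts and higher numbers for an effect only at larger amounts of compound), compound 1 gives 23000 nM
compound 2 `Cc1c(Cl)cccc1-c1cccc(COc2ccc([C@H](CC(=O)O)c3nccn3C)cc2)c1` — in this assay compound 2 gives 61 nM
compound 3 `Cn1ccnc1[C@@H](CC(=O)O)c1ccc(OCc2cccc(-c3ccc(Cl)cc3Cl)c2)cc1` — in this assay compound 3 gives 69 nM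

Compound 2 has the lowest of the three numbers in this assay. Its nearest neighbour is compound 3, with a 1.1-fold higher number from compound 2 to compound 3 (0.05 log units; within the scatter), a difference within the scatter; its furthest is compound 1, with a 380-fold lower number from compound 1 to compound 2 (2.58 log units; beyond the scatter).

Compound 4 `Cc1cccc(C)c1-c1cccc(COc2ccc([C@H](CC(=O)O)c3nccn3C)cc2)c1` has not been measured. It differs from compound 2 in one place: 2,6-dimethylphenyl in place of 3-chloro-2-methylphenyl on an aromatic carbon. For the measured compounds named here, the steps that bear on this change are the two large ones away from the 2-(methylsulfonyl)phenyl group, a 380-fold lower number from compound 1 to compound 2 (2.58 log units; beyond the scatter) and a 330-fold lower number from compound 1 to compound 3 (2.52 log units; beyond the scatter), and the small one between the two other rings, a 1.1-fold higher number from compound 2 to compound 3 (0.05 log units; within the scatter). Since compound 4, like compound 2 and compound 3, carries a six-membered aromatic ring of carbon only with no donors or acceptors, a step in this assay of at most modest size is expected, if anything toward a higher number. For compound 4 the estimate in this assay is 85 nM, with a range from 25 nM to 300 nM. This estimate corresponds to an expected step of a 1.4-fold higher number from compound 2 to compound 4 (0.14 log units; within the scatter).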

Compound 4, half-maximal effective concentration: 58 nM
Estimate against measurement, compound 4: 1.5-fold (0.17 log units) above; the measured number falls inside the stated range.
By their numbers in this assay, from the lowest: compounds 4, 2 and 3 (each within the scatter of the next); then compound 1.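

On this aromatic carbon, meta to a large group, 2,6-dimethylphenyl, which carries no chlorine, lies within the scatter of both chlorine-bearing rings in this assay (a 1.1-fold lower number from compound 2 to compound 4 (0.02 log units; within the scatter); a 1.2-fold lower number from compound 3 to compound 4 (0.08 log units; within the scatter)). A third ring thus stands far from the 2-(methylsulfonyl)phenyl compound (a 400-fold lower number from compound 1 to compound 4 (2.60 log units; beyond the scatter)), so among the compounds shown, chlorine is not required for a number in the range of compound 2 and compound 3. Nothing available explains why these three rings match or why compound 1 stands apart.

Going by these compounds, whether a ring bearing a methoxy group or an amine at this place would fall with compound 4 or with compound 1 remains open. The compounds shown also leave open where a plain phenyl ring, with neither methyl nor chlorine, would fall.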